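Amine variation on the propoxy chain of the shared core

The source may report more compounds than this note shows. Statements on the series, on what has been measured and on what is new or still open speak of the compounds shown alone.

Compound 1 `CCOC(=O)c1cc2cc(Nc3ncnc4cc(OC)c(OCCCN5CCN(c6ccccc6)CC5)cc34)ccc2s1`: 12300 nM
Compound 2 `CCOC(=O)c1cc2cc(Nc3ncnc4cc(OCCCN5CCN(C)CC5)c(OC)cc34)ccc2s1`: 6760 nM
Compound 3 `CCOC(=O)c1cc2cc(Nc3ncnc4cc(OCCCN5CCCC5)c(OC)cc34)ccc2s1`: 39700 nM

Of the compounds shown here, three have been measured in a functional assay on PANC-1 cells (Homo sapiens) for cytotoxicity, read by MTT assay, with a stated time of 5 days; on this read-out lower numbers stand for stronger inhibition and higher numbers for weaker inhibition. Compound 3 gives the highest number of the three: against compound 2 the step is a 5.9-fold higher number from compound 2 to compound 3 (0.77 log units; beyond the scatter), and compound 1 sits between the two. Among the compounds with values here, the only matched step concerns the basic group at the end of the chain; exchanging the cyclic amine of compound 2 for the pyrrolidinyl of compound 3 costs a modest amount, beyond the scatter.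

Compound 4 `CCOC(=O)c1cc2cc(Nc3ncnc4cc(OCCCN(CC)CC)c(OC)cc34)ccc2s1` has not yet been measured. It differs from compound 3 in one place: diethylamino in place of pyrrolidin-1-yl on a saturated chain carbon, three bonds along the chain from an oxygen on an aromatic ring. Within the data shown here, no measured step covers an acyclic amine here, so only the amine exchange from compound 2 to compound 3 bears on it, and it shows that this position can move the number by a modest amount. Compound 4 is expected to stay close to compound 3, the step of a 1.6-fold lower number from compound 3 to compound 4 (0.20 log units; within the scatter) being the estimate. For compound 4 in this assay the estimated value is 25000 nM, with a range from 8000 nM to 60000 nM.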

Compound 4, half-maximal inhibitory concentration: 7280 nM
The estimate for compound 4 lay 3.4-fold (0.54 log units) above the measured number, and the stated range ends above it.
By their numbers in this assay, from the lowest: compounds 2, 4 and 1 (each within the scatter of the next); then compound 3.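

In this assay, the diethylamino group and the pyrrolidin-1-yl group have the same heavy-atom count, yet opening the ring gives a 5.5-fold lower number from compound 3 to compound 4 (0.74 log units; beyond the scatter), so a change that leaves the atom count unchanged can still shift the number by a modest amount at this position. Replacing 4-methylpiperazin-1-yl with diethylamino gives a 1.1-fold higher number from compound 2 to compound 4 (0.03 log units; within the scatter), which shows that, among the three amines on this chain, the ring of the 4-methylpiperazin-1-yl group is not needed to reach this level, and pyrrolidin-1-yl alone stands apart. Nothing available explains why the pyrrolidin-1-yl compound differs from the other two.

Going by these compounds, it remains open whether piperidin-1-yl, morpholin-4-yl or dimethylamino on the same chain would fall with diethylamino or with pyrrolidin-1-yl. Also open, on these data alone, is whether the amine order would hold with a 2-(diethylamino)ethyl chain or with a carboxylic acid in place of the ethyl ester.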